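Restoring an aryl amine on the shared core

A few compounds are considered here, and "the series" means these few. Any claim that something is new, unique, unknown or untested is made for them only; others in the source may bear on it.

Measured compounds:
compound 1 `CCN1CCN(c2ccc(Nc3ncc4c(n3)N(C)C(=O)N(c3cc(NC(=O)c5cccc(C(F)(F)F)c5)ccc3C)C4)cc2)CC1`, 559 nM
compound 2 `Cc1ccc(NC(=O)c2cccc(C(F)(F)F)c2)cc1N1Cc2cnc(Nc3cnn(C)c3)nc2N(C)C1=O`, 352 nM
compound 3 `Cc1ccc(NC(=O)c2cccc(C(F)(F)F)c2)cc1N1Cc2cnc(NCCO)nc2N(C)C1=O`, 3290 nM

In an ADME assay on BaF3 cells (Mus musculus) for inhibition, read by CellTiter-Glo, with a stated time of 72 h (a higher number here means a weaker inhibitor of growth, a lower number a stronger inhibitor of growth), compound 3 gives the highest number of the three: compound 1 gives 559 nM and compound 2 gives 352 nM, so compound 3 is the weakest inhibitor in this set. Compound 4 `Cc1cc(Nc2ncc3c(n2)N(C)C(=O)N(c2cc(NC(=O)c4cccc(C(F)(F)F)c4)ccc2C)C3)n(C)n1` has not yet been measured. It differs from compound 3 in one place: 1,3-dimethyl-1H-pyrazol-5-yl in place of 2-hydroxyethyl on a nitrogen on an aromatic ring.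

For the measured compounds named here, the one measured step that bears on this change runs the other way. Replacing an aromatic amine substituent with 2-hydroxyethyl gave a 9.3-fold higher number from compound 2 to compound 3 (0.97 log units; beyond the scatter). Compound 4 reverses that kind of change, bringing a pyrazolyl group back onto the same nitrogen, though a 1,3-dimethyl-1H-pyrazol-5-yl rather than the group in compound 2. Going by the values given here, no measured pair shows how these two pyrazolyl groups compare with each other.

Compound 4 is therefore expected to give a clearly lower number than compound 3, a step of about a 4.7-fold lower number from compound 3 to compound 4 (0.67 log units; beyond the scatter) in this assay. The estimate for compound 4 is 700 nM, with a range from 200 nM to 2500 nM.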

Compound 4, concentration for 50% growth inhibition: 2060 nM
The estimate for compound 4 lay 2.9-fold (0.47 log units) below the measured number, within the range that was stated.
By their numbers in this assay, from the lowest: compounds 2 and 1 (each within the scatter of the next); then compounds 4 and 3 (each within the scatter of the next).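

In this assay, a pyrazolyl group on this nitrogen does not by itself bring back the number of compound 2. Putting 1,3-dimethyl-1H-pyrazol-5-yl in place of 2-hydroxyethyl gives a 1.6-fold lower number from compound 3 to compound 4 (0.20 log units; within the scatter), whereas the same group in place of 1-methyl-1H-pyrazol-4-yl gives a 5.9-fold higher number from compound 2 to compound 4 (0.77 log units; beyond the scatter). At this position, then, the particular pyrazolyl group matters, not only the presence of an aromatic ring on the nitrogen, although nothing available explains the difference between the two groups.

Compound 2 and compound 4 differ both in where the ring is attached and in its extra methyl, so the compounds shown leave open which of these accounts for the step. A 1-methyl-1H-pyrazol-5-yl group on the same nitrogen would separate the two.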